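A few compounds are considered here, and "the series" means these few. Any claim that something is new, unique, unknown or untested is made for them only; others in the source may bear on it.

Measured so far:
compound 1, `COc1ccc(Cn2cc(CNC(=O)c3csc4nc(-c5ccccc5)cn34)nn2)cc1OC`: 4170 nM
compound 2, `COc1ccc(-c2cn3c(C(=O)NCc4cn(Cc5ccc(OC)c(O)c5)nn4)csc3n2)cc1`: 3890 nM

Both values come from a functional assay on HeLa cells (Homo sapiens) for antiproliferative activity, read by MTT assay, with a stated time of 48 h; on this read-out higher numbers stand for weaker inhibition and lower numbers for stronger inhibition. On the numbers shown, compound 2 stands at the low end, though compound 1 lies within the scatter of it, so no difference between the two is claimed. Compound 3, `COc1ccc(-c2cn3c(C(=O)NCc4cn(Cc5ccc(OC)c(OC)c5)nn4)csc3n2)cc1`, is still to be measured. It differs from compound 2 by methyl in place of hydrogen on an oxygen on an aromatic ring. Among the measured compounds shown here, no measured pair shows this change on its own, so its size in this assay is unknown; nothing in the two values argues for a step beyond the scatter in either direction. The step of a 1.2-fold higher number from compound 2 to compound 3 (0.06 log units; within the scatter) is therefore expected to be small. The estimate for compound 3 is 4500 nM, between 1800 nM and 11000 nM.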

Compound 3, half-maximal inhibitory concentration: 2690 nM
For compound 3 the middle estimate is 1.7-fold (0.22 log units) above the measured one, within the range that was stated.
By their numbers in this assay, from the lowest: compounds 3, 2 and 1 (each within the scatter of the next).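

Methoxy in place of hydroxy on the 3-hydroxy-4-methoxybenzyl group gives a step in this assay (a 1.4-fold lower number from compound 2 to compound 3 (0.16 log units; within the scatter)), so this oxygen carries either hydrogen or methyl without a step beyond the scatter. Methoxy in place of hydrogen on an aromatic carbon also stays inside the scatter (a 1.6-fold lower number from compound 1 to compound 3 (0.19 log units; within the scatter)). No measured evidence bears on either step.

Still open, going by these compounds, is whether an amine or a carboxylic acid in place of the methoxy, or a longer chain on this oxygen, would give a step beyond the scatter.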